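Exchanging One Five-Membered Ring for Another on the Core

The source may report more compounds than this note shows. Statements on the series, on what has been measured and on what is new or still open speak of the compounds shown alone.

Compound 2 `C[C@H](c1ccccc1)N1C(=O)O[C@](Cc2ccccc2)(c2nnc(-c3ccccc3)[nH]2)C1=O` was tested in an ADME assay (liver) for metabolic stability, with Liver microsome (Homo sapiens) as the target, using microsomes, with a stated time of 0.5 h, tested at 1 uM (on this read-out lower numbers stand for a less stable compound and higher numbers for a more stable compound), and gives 78%. Within the data shown here, its only measured neighbour, compound 1 `C[C@H](c1ccccc1)N1C(=O)O[C@](Cc2ccccc2)(c2nc(-c3ccccc3)co2)C1=O`, gives 73% in this assay. The step of a number 5 percentage points higher from compound 1 to compound 2 (within the scatter) lies within the scatter, so compound 2 stands together with compound 1 rather than apart from it. Compound 3 `C[C@H](c1ccccc1)N1C(=O)O[C@](Cc2ccccc2)(c2nnc(-c3ccccc3)o2)C1=O` has not yet been measured; it differs from compound 2 by 5-phenyl-1,3,4-oxadiazol-2-yl in place of 5-phenyl-4H-1,2,4-triazol-3-yl on a saturated ring carbon. Among the measured compounds shown here, the one measured step that bears on this change is the earlier swap of one five-membered aromatic ring bearing a phenyl group for another, which gave a number 5 percentage points higher from compound 1 to compound 2 (within the scatter). On that basis the expected step is a number 3 percentage points lower from compound 2 to compound 3 (within the scatter), with no movement beyond the scatter in either direction. Compound 3 is therefore estimated to give 75% in this assay, within a range from 58% to 90%.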

Compound 3, percent of the compound remaining: 82%
Compound 3: the middle estimate sits 7 percentage points below what was measured; low and high end bracket the measured number.
By their numbers in this assay, from the lowest: compounds 1, 2 and 3 (each within the scatter of the next).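

In this assay, this saturated ring carbon now carries a third five-membered aromatic ring bearing a phenyl group, and the step of a number 4 percentage points higher from compound 2 to compound 3 (within the scatter) stays small even though 5-phenyl-1,3,4-oxadiazol-2-yl has 0 hydrogen-bond donors where 5-phenyl-4H-1,2,4-triazol-3-yl has 1 hydrogen-bond donor. The direct step of a number 9 percentage points higher from compound 1 to compound 3 (within the scatter) also stays inside the scatter, so all three ring exchanges leave the compounds indistinguishable in this read-out. No supporting data explain this similarity.

The compounds shown all keep a five-membered aromatic ring bearing an unsubstituted phenyl group at this position. Going by these compounds, it remains open how the read-out would respond to a carboxylic acid or an amine at this position, or to a methoxy group on that phenyl ring.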